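A few compounds are considered here, and "the series" means these few. Any claim that something is new, unique, unknown or untested is made for them only; others in the source may bear on it.

Compound 1 `CN(C)CCCNc1nc(-c2ccc(NC(=O)Nc3ccccc3F)cc2)nc2ccsc12`, compound 2 `CN(C)CCCNc1nc(-c2ccc(NC(=O)Nc3ccccc3Cl)cc2)nc2ccsc12` and compound 3 `CN(C)CCCNc1nc(-c2ccc(NC(=O)Nc3ccc(Cl)cc3)cc2)nc2c(Cl)c(Cl)sc12` were measured in a functional assay on NCI-H460 cells (Homo sapiens) for cytotoxicity, read by MTT assay, with a stated time of 72 h; on this read-out lower numbers stand for stronger inhibition and higher numbers for weaker inhibition. Compound 1 gives 530 nM, compound 2 gives 430 nM and compound 3 gives 230 nM.

Compound 3 has the lowest of these three numbers; its gap to compound 2 lies within the usual scatter of repeated measurements, while its gap to compound 1 lies beyond it, so only a modest separation is shown. Compound 4 `CN(C)CCCNc1nc(-c2ccc(NC(=O)Nc3ccc(Cl)cc3Cl)cc2)nc2c(Cl)c(Cl)sc12` shares the core of compound 3 and differs from it by chloro in place of hydrogen on an aromatic carbon. Among the measured compounds shown here, the only measured step on the 4-chlorophenyl part of the urea is a 1.2-fold lower number from compound 1 to compound 2 (0.09 log units; within the scatter), and that step swapped one halogen for another rather than adding one, so it bears only loosely on the present change. For the measured compounds named here, no measured pair shows a hydrogen replaced by chloro. The expectation is therefore a step of a 1.2-fold lower number from compound 3 to compound 4 (0.06 log units; within the scatter), small enough that it may fall within the scatter. Compound 4 is expected to give 200 nM, within a range from 80 nM to 500 nM.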

Compound 4, half-maximal inhibitory concentration: 980 nM
For compound 4 the middle estimate is 4.9-fold (0.69 log units) below the measured one, outside the stated range (above it).
By their numbers in this assay, from the lowest: compounds 3, 2, 1 and 4 (each within the scatter of the next, the first and the last beyond it).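

Adding one chloro ortho to a large group, which turns 4-chlorophenyl into 2,4-dichlorophenyl, gives in this assay a 4.3-fold higher number from compound 3 to compound 4 (0.63 log units; beyond the scatter), a weakening of inhibition that lies beyond the scatter. Among the compounds shown here, this is the first measured step in which a hydrogen gives way to a chloro, and it shows that this place on the ring does not accept the change freely. The earlier halogen swap, a 1.2-fold lower number from compound 1 to compound 2 (0.09 log units; within the scatter), gave no sign of such a loss.

On these data alone, what a methyl or a methoxy group would do at the same place remains open. So does whether the same added chloro would cost as much on the core of compound 1. Nothing measured here accounts for the weaker inhibition of compound 4.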